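From 4-bromophenyl to phenethyl on a triple-bonded carbon

The compounds below may be only part of what the source reports. "The series", "measured", "known", "first", "only" and "open" are said of these compounds alone.

Values in an ADME assay on WI-38 cells (Homo sapiens) for cytotoxicity, read by MTT assay, with a stated time of 3 days; on this read-out higher numbers stand for weaker inhibition and lower numbers for stronger inhibition:
Compound 1 `Cc1ccc(C#Cc2cn(C/C=C\CN3C(=O)c4ccccc4C3=O)c(=O)[nH]c2=O)cc1`: > 100000 nM
Compound 2 `O=C1c2ccccc2C(=O)N1C/C=C\Cn1cc(C#Cc2ccc(Br)cc2)c(=O)[nH]c1=O`: 47000 nM
Compound 3 `CCCCc1ccc(C#Cc2cn(C/C=C/CN3C(=O)c4ccccc4C3=O)c(=O)[nH]c2=O)cc1`: 40000 nM

Compound 1 shows the entry > 100000 nM, which is a limit of the assay, not a number (the limit of > 100000 nM in this assay, at which 1 of the 3 values shown sits). For the measured compounds named here, compound 2 and compound 3 hold the only true numbers, and these lie within the scatter of each other. Compound 4 `O=C1c2ccccc2C(=O)N1C/C=C\Cn1cc(C#CCCc2ccccc2)c(=O)[nH]c1=O` differs from compound 2 in one place, with phenethyl in place of 4-bromophenyl on a triple-bonded carbon. Going by the values given here, one measured step bears on this change, with bromo in place of methyl on an aromatic carbon: an at least 2.1-fold lower number from compound 1 to compound 2 (0.32 log units; beyond the scatter). Compound 4 carries no bromo, so given that step, a modest shift toward higher numbers is expected in this assay. The estimated step is a 1.5-fold higher number from compound 2 to compound 4 (0.17 log units; within the scatter). For compound 4 the estimated value is 70000 nM, with an expected range from 30000 nM to 100000 nM.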

Compound 4, half-maximal inhibitory concentration: > 100000 nM
Compound 4: no number, only a limit; the forecaster's own chance of this, stated with the estimate: 35%; middle value at least 1.4-fold (0.15 log units) away from the limit.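

In this assay, phenethyl in place of 4-bromophenyl on the triple-bonded carbon gives an at least 2.1-fold higher number from compound 2 to compound 4 (0.32 log units; beyond the scatter), so the group at this position can shift the read-out towards weaker inhibition. Compound 4 shows a limit of the assay, not a number: the limit of > 100000 nM in this assay, at which 2 of the 4 values shown sit. The step from compound 1 to compound 4 cannot be read, as both entries are limits.

The compounds shown do not separate the loss of the bromo from the entry of phenethyl, since compound 4 carries both changes. On these data alone, how an amine, a carboxylic acid or a longer chain on this carbon would read in this assay also stays open.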